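A thiophene exchange on the shared core

This account rests on a few compounds, and the source may have more. Where it says the series, first, only, none or still open, it means among the compounds named here.

Measured so far:
Compound 1 `N=C(N)N/N=C/c1c(-c2ccsc2)nc2n1CCS2`: 21900 nM
Compound 2 `Cc1cc(-c2nc3n(c2/C=N/NC(=N)N)CCS3)c(C)s1`: 15500 nM

Among the compounds with values here, in a functional assay on cells (Melanoma cell, Homo sapiens) for inhibition (on this read-out higher numbers stand for weaker inhibition of growth and lower numbers for stronger inhibition of growth), compound 2 gives 15500 nM, and this value lies within the scatter of the one for compound 1, 21900 nM. Compound 3 `N=C(N)N/N=C/c1c(-c2cccs2)nc2n1CCS2` keeps the shared core and differs from compound 2 in one group: thiophen-2-yl in place of 2,5-dimethylthiophen-3-yl on an aromatic carbon. Within the data shown here, only one measured step bears on this change: a 1.4-fold lower number from compound 1 to compound 2 (0.15 log units; within the scatter). That step exchanged one thiophene group for another and stayed within the scatter. Among the measured compounds shown here, no measured compound carries thiophen-2-yl, so that group remains untested. No step beyond the scatter is therefore expected in this assay, in either direction. The expected step is a 1.2-fold higher number from compound 2 to compound 3 (0.09 log units; within the scatter). For compound 3 the estimated value is 19000 nM, with an expected range from 8000 nM to 45000 nM.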

Compound 3, concentration for 50% growth inhibition: 21400 nM
Beside the measured number, compound 3's estimate is 1.1-fold (0.05 log units) below it; low and high end bracket the measured number.
By their numbers in this assay, from the lowest: compounds 2, 3 and 1 (each within the scatter of the next).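

In this assay, the new group thiophen-2-yl gives a 1.4-fold higher number from compound 2 to compound 3 (0.14 log units; within the scatter), and its exchange for thiophen-3-yl gives a 1.0-fold lower number from compound 1 to compound 3 (0.01 log units; within the scatter). Within the data shown here, until now only one exchange at this aromatic carbon had been read, so the result adds that moving from thiophen-3-yl to thiophen-2-yl, like adding the two methyl groups of 2,5-dimethylthiophen-3-yl, gives no step beyond the scatter among compound 1, compound 2 and compound 3. No supporting data are at hand to explain why these values lie so close together.

As far as these compounds go, all three compounds carry a thiophene at this position, so it remains open whether a phenyl ring, a pyridine or an amine there would give a step beyond the scatter. From the compounds shown here alone, it also remains open whether any group at this carbon can change the read-out at all.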